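Hydroxy analogue of compound 1: expected inhibition

The source may hold more compounds than are shown below. What is called first, only, known or untested is meant among the compounds shown, and "the series" means these compounds.

In an assay on COS-7 cells for inhibition of patatin-like phospholipase domain-containing protein 2 (Mus musculus), tested at 200 uM (on this read-out lower numbers stand for less inhibition and higher numbers for more inhibition at the one concentration tested (going by the name of the read-out)), compound 1 `CCOC(=O)c1cccc(-c2ccc(OCC)cc2)c1` gives 87%. Compound 2 `CCOC(=O)c1ccc(-c2ccc(OCC)cc2)s1` gives 81%, a number within the usual scatter of that of compound 1. Compound 3 `CCOC(=O)c1ccc(-c2ccc(OCC)cc2)[nH]1` gives 44%, a number beyond the scatter below compound 1, so compound 1 and compound 2 lie together at the upper end of the three measured numbers and compound 3 well below them. Compound 4 `CCOC(=O)c1cccc(-c2ccc(O)cc2)c1` is not yet measured. It differs from compound 1 in one place: hydrogen in place of ethyl on an oxygen on an aromatic ring. Within the data shown here, no measured pair shows this change, so nothing among the measured compounds sizes it. In this assay a modest loss is expected, a number 17 percentage points lower from compound 1 to compound 4 (beyond the scatter), possibly still within the scatter. Compound 4 is estimated at 70%, with a range from 45% to 90%.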

Compound 4, a percentage reported as inhibition, at one concentration (the size of the read-out at that concentration, not a potency): 77%
Compound 4: the middle estimate sits 7 percentage points below what was measured, within the range that was stated.
By their numbers in this assay, from the lowest: compound 3; then compounds 4, 2 and 1 (each within the scatter of the next).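

In this assay the change from ethoxy to hydroxy reads as a number 10 percentage points lower from compound 1 to compound 4 (within the scatter) on the core of compound 1. The ethyl group on this oxygen is therefore not required to keep the read-out at the one concentration tested, on this core. The earlier compounds shown here all carry ethoxy and could not show this. Nothing measured explains the step.

From the compounds shown here alone, it remains open whether a longer chain such as butoxy, or an amine in place of the ethoxy, would keep the read-out. Going by these compounds, whether hydroxy behaves alike on the cores of compound 2 and compound 3 also remains open.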